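Aryl in place of cyclohexyl on a shared core

This account rests on a few compounds, and the source may have more. Where it says the series, first, only, none or still open, it means among the compounds named here.

Of the compounds shown here, three built on a shared core have been measured. Compound 1 `Fc1cc(F)c(Nc2nc3nonc3nc2Nc2c(F)cc(F)cc2F)c(F)c1` gives 1100 nM in an assay on mitochondria from L6 cells (Rattus norvegicus) for activation, with a stated time of 90 min; on this read-out lower numbers stand for an effect already at smaller amounts and higher numbers for an effect only at larger amounts of compound. Compound 2 `FC(F)(F)Oc1ccc(Nc2nc3nonc3nc2Nc2ccc(OC(F)(F)F)cc2)cc1` reaches only a limit of this assay, < 5000 nM. Compound 3 `Fc1ccccc1Nc1nc2nonc2nc1NC1CCCCC1` gives 13400 nM in this assay, the highest of the two numbers; the nearest number is that of compound 1, and the gap between them lies beyond the scatter. For compound 2 only a limit is known, (the limit of < 5000 nM in this assay, at which 1 of the 3 values shown sits). Compound 4 `COc1ccc(Nc2nc3nonc3nc2Nc2ccccc2F)cc1` has not yet been measured. It differs from compound 3 in one place: 4-methoxyphenyl in place of cyclohexyl on a nitrogen on an aromatic ring. The account therefore rests on a single comparison: compound 1, which also carries an aromatic ring on this nitrogen, gives 1100 nM, a lower number than compound 3. On that basis the step from compound 3 to compound 4 is expected to be a 3.8-fold lower number from compound 3 to compound 4 (0.58 log units; beyond the scatter), towards a lower number. For compound 4 the estimate in this assay is 3500 nM, with a range from 900 nM to 13000 nM.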

Compound 4, half-maximal effective concentration: 1600 nM
The estimate for compound 4 lay 2.2-fold (0.34 log units) above the measured number; the range from low to high includes it.
By their numbers in this assay, from the lowest: compounds 1 and 4 (each within the scatter of the next); then compound 3.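

The earlier compounds shown here offered no pair that differs in one place; in this assay this position now shows an 8.4-fold lower number from compound 3 to compound 4 (0.92 log units; beyond the scatter) when 4-methoxyphenyl stands in place of cyclohexyl on a nitrogen on an aromatic ring. The change is a single exchange, so the number at this nitrogen is shown to respond to the group it carries, with the rest of the molecule held constant. The exchange alters more than one thing at once, since the entering group brings an aromatic ring, an oxygen and a hydrogen-bond acceptor, and nothing at hand gives a cause for the step.

As far as these compounds go, whether the aromatic ring or its methoxy group carries the step remains open. Plain phenyl on this nitrogen, or an amine or a carboxylic acid in place of the methoxy, would help to separate the two.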